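From thiophen-2-yl to 4-fluorobenzyl on a shared core

This account rests on a few compounds, and the source may have more. Where it says the series, first, only, none or still open, it means among the compounds named here.

In a functional assay on RS4-11 cells (Homo sapiens) for inhibition, read by CCK-8 assay, with a stated time of 48 h (a lower number here means a stronger inhibitor, a higher number a weaker inhibitor), three compounds sharing a core have been tested so far. Compound 1 (`Cc1ccc(S(=O)(=O)Oc2ccccc2/C=C(\C#N)C(=O)Nc2nnc(C)s2)cc1`) gives > 20000 nM as a limit of the assay and not a number. Compound 2 (`COc1ccc(S(=O)(=O)Oc2ccccc2/C=C(\C#N)C(=O)Nc2nnc(-c3cccs3)s2)cc1`) gives 4750 nM and compound 3 (`COc1ccc(Cc2nnc(NC(=O)/C(C#N)=C/c3ccccc3OS(=O)(=O)c3ccc([N+](=O)[O-])cc3)s2)cc1`) gives 3670 nM in the same test, two values within the scatter of each other. Compound 2 therefore stands level with compound 3 among the numbers available.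

Compound 4 (`COc1ccc(S(=O)(=O)Oc2ccccc2/C=C(\C#N)C(=O)Nc2nnc(Cc3ccc(F)cc3)s2)cc1`) has yet to be measured. It differs from compound 2 at one place (4-fluorobenzyl in place of thiophen-2-yl on an aromatic carbon) with 4-fluorobenzyl in place of thiophen-2-yl on an aromatic carbon of a five-membered aromatic ring with 2 nitrogen and 1 sulfur. Within the data shown here, no measured pair differs in one place alone, so no direct step sizes this change. The closest guide is compound 3, which also carries a benzyl group at that place and gives 3670 nM in this assay as well. No change beyond the scatter is therefore expected in this assay in either direction. The expected change is a 1.4-fold lower number from compound 2 to compound 4 (0.13 log units; within the scatter) and is estimated to stay within the scatter. For compound 4 the expected value is 3500 nM within a range of 1300 nM to 9500 nM as estimated here.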

Compound 4, half-maximal inhibitory concentration: 1210 nM
Compound 4: the middle estimate sits 2.9-fold (0.46 log units) above what was measured; the measured number lies below the stated range.
By their numbers in this assay, from the lowest: compound 4; then compounds 3 and 2 (each within the scatter of the next). At a limit, above all of these: compound 1.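

In this assay, among these compounds, replacing thiophen-2-yl with 4-fluorobenzyl on an aromatic carbon of the five-membered aromatic ring with 2 nitrogen and 1 sulfur gives a 3.9-fold lower number from compound 2 to compound 4 (0.59 log units; beyond the scatter), the first step that can be read directly. Among the compounds shown here, it shows that this position responds to the group it carries by more than the scatter, something the earlier compounds could not show, as none of them differed from another in one place alone. The entering group brings a six-membered aromatic ring of carbon only and a fluorine, while the leaving group has a five-membered aromatic ring with 1 hetero atom, but this single step cannot separate these features, and nothing shown gives a cause for it.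

The compounds shown leave open whether the fluorine contributes at all, which a plain benzyl group on the same core would address, and whether a pyridine ring or an amine would be tolerated at this position. From the compounds shown here alone, it also remains open whether the step would hold with the other aryl groups on the sulfonate.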